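The source may report more compounds than this note shows. Statements on the series, on what has been measured and on what is new or still open speak of the compounds shown alone.

Measured so far:
- compound 1 `COc1ccc(Nc2nc(NCCCO)c3ccccc3n2)cc1` gives 20300 nM in a functional assay on KB cells (Homo sapiens) for antiproliferative activity, read by sulforhodamine B assay, with a stated time of 48 h; on this read-out lower numbers stand for stronger inhibition of growth and higher numbers for weaker inhibition of growth
- compound 2 `CNc1nc(Nc2ccc(OC)cc2)nc2ccccc12` gives 14800 nM in this assay

Compound 2 has only compound 1 for comparison, and the two numbers do not separate: the step is a 1.4-fold lower number from compound 1 to compound 2 (0.14 log units; within the scatter) and does not order the pair. Both values belong to the same high range on this read-out.

Next is compound 3 `COc1ccc(Nc2nc(NC3CC3)c3ccccc3n2)cc1` with the change cyclopropyl in place of methyl on a nitrogen on an aromatic ring in the same substituent on the amine: cyclopropyl in place of methyl on a nitrogen on an aromatic ring.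

For the measured compounds named here, one measured step bears on this. Going to compound 2 from compound 1 also altered the group on that nitrogen, and the size of a 1.4-fold lower number from compound 1 to compound 2 (0.14 log units; within the scatter) in this assay gives no sign that this group moves the number much. Going by the values given here, no compound with a ring on this nitrogen has been measured, so the evidence is thin and no direction can be set. The expected step is a 1.1-fold lower number from compound 2 to compound 3 (0.06 log units; within the scatter) and it is estimated to stay within the scatter. Compound 3 is estimated at 13000 nM with a range from 5000 nM to 35000 nM as the expected span.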

Compound 3, concentration for 50% growth inhibition: 13300 nM
Beside the measured number, compound 3's estimate is 1.0-fold (0.01 log units) below it; low and high end bracket the measured number.
By their numbers in this assay, from the lowest: compounds 3, 2 and 1 (each within the scatter of the next).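

Working notes on the group on the nitrogen, in this assay: this is the first reading with a ring at this position, and cyclopropyl in place of methyl gives (a 1.1-fold lower number from compound 2 to compound 3 (0.05 log units; within the scatter)), while cyclopropyl in place of 3-hydroxypropyl gives (a 1.5-fold lower number from compound 1 to compound 3 (0.18 log units; within the scatter)). Neither step separates the pair it joins, so across compounds 1, 2 and 3 neither the three-membered ring nor the choice among these three groups orders the series, and all three values stay in one high range on this read-out. No supporting measurement is available to explain why these three values sit together.

Still open, from the compounds shown here alone, is whether a larger ring such as cyclohexyl, an aromatic group such as benzyl, or a chain ending in an amine on this nitrogen would leave that range. Also open, going by these compounds, is whether replacing the methoxy group, which all three compounds share, with a chlorine atom would shift the number further than any change on this nitrogen has so far.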